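Propyl step on compound 2

This account rests on a few compounds, and the source may have more. Where it says the series, first, only, none or still open, it means among the compounds named here.

Going by the values given here, in a functional assay on HeLa cells (Homo sapiens) for antiproliferative activity, read by sulforhodamine B assay (on this read-out lower numbers stand for stronger inhibition of growth and higher numbers for weaker inhibition of growth), compound 1 (`c1ccc(COC[C@H]2OCC[C@@H](OCc3ccccc3)[C@@H]2OCc2ccccc2)cc1`) reads 33300 nM and is the only measured number so far. Compound 2 (`O[C@H]1CO[C@H](COCc2ccccc2)[C@@H](OCc2ccccc2)[C@@H]1OCc1ccccc1`) gives > 50000 nM as a limit of the assay and not as a number. Compound 3 (`CCC[C@@H]1O[C@H](COCc2ccccc2)[C@@H](OCc2ccccc2)[C@H](OCc2ccccc2)[C@H]1O`) follows from compound 2 by propyl in place of hydrogen on a saturated ring carbon with propyl in place of hydrogen on a saturated ring carbon, next to the ring oxygen. Among the compounds with values here, the sole measured step is an at least 1.5-fold higher number from compound 1 to compound 2 (0.17 log units; that floor lies within the scatter) and it concerns hydroxy in place of hydrogen, so it offers only a loose guide to a propyl change. A modest move toward a lower number is expected, and the estimated step is an at least 1.4-fold lower number from compound 2 to compound 3 (0.15 log units; that floor lies within the scatter) starting from a limit. For compound 3 the estimate is 35000 nM with an expected range from 12000 nM to 70000 nM and a real chance of another limit.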

Compound 3, concentration for 50% growth inhibition: 18900 nM
For compound 3 the middle estimate is 1.9-fold (0.27 log units) above the measured one; low and high end bracket the measured number.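

In this assay the change is an at least 2.6-fold lower number from compound 2 to compound 3 (0.42 log units; beyond the scatter) for propyl in place of hydrogen on a saturated ring carbon, next to the ring oxygen. Going by these compounds alone, this is the first step that clears the scatter, and it shows that this ring carbon, next to the ring atom that bears a hydroxy group, can carry a propyl group with stronger inhibition of growth, not weaker. The step remains a floor, since compound 2 stands at a limit of the assay and not at a number: the limit of > 50000 nM in this assay, at which 1 of the 3 values shown sits.

As far as these compounds go, whether the gain follows chain length remains open, and a methyl or a butyl chain on this carbon would address that. An amine or a carboxylic acid at the end of the propyl chain would test whether a plain carbon chain is needed.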